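Fluoro for Chloro at the Amide-Side Ring of Compound 2

The source may report more compounds than this note shows. Statements on the series, on what has been measured and on what is new or still open speak of the compounds shown alone.

Going by the values given here, compound 2 `O=C(CSc1nc(Nc2ccccc2)c2ccccc2n1)Nc1ccc(Cl)c(Cl)c1` holds the higher of the two numbers measured so far: in a functional assay on NCI-H1975 cells (Homo sapiens) for inhibition, read by MTT assay, with a stated time of 72 h (on this read-out lower numbers stand for stronger inhibition and higher numbers for weaker inhibition), compound 2 gives 10400 nM. Its nearest measured relative is compound 1 `O=C(CSc1nc(Nc2ccccc2)c2ccccc2n1)Nc1cccc(F)c1`, which in this assay gives 6790 nM; the step of a 1.5-fold higher number from compound 1 to compound 2 (0.19 log units; within the scatter) is the only one on record and lies within the scatter. Compound 3 `O=C(CSc1nc(Nc2ccccc2)c2ccccc2n1)Nc1ccc(F)c(Cl)c1` is not yet measured. It differs from compound 2 by fluoro in place of chloro on an aromatic carbon, a halogen exchange that cuts the same distal ring already varied between compound 1 and compound 2. That single step bears on the question: it was small, and nothing in it points to a large effect from a further swap of one halogen for another. The account therefore expects for compound 3 a number within the scatter of compound 2, perhaps slightly lower, with the step estimated as a 1.3-fold lower number from compound 2 to compound 3 (0.11 log units; within the scatter). Compound 3 is expected to give about 8000 nM, estimated to fall between 3500 nM and 20000 nM.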

Compound 3, half-maximal inhibitory concentration: 9390 nM
Beside the measured number, compound 3's estimate is 1.2-fold (0.07 log units) below it, within the range that was stated.
By their numbers in this assay, from the lowest: compounds 1, 3 and 2 (each within the scatter of the next).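

In this assay, fluoro in place of chloro on an aromatic carbon, ortho to a chloro group and para to a large group, comes to a 1.1-fold lower number from compound 2 to compound 3 (0.04 log units; within the scatter), so this one-atom halogen exchange at this position leaves the read-out within the scatter. The wider change of 3-fluorophenyl to 3-chloro-4-fluorophenyl on the amide-type nitrogen comes to a 1.4-fold higher number from compound 1 to compound 3 (0.14 log units; within the scatter), so all three halogen patterns on this ring, in compound 1, compound 2 and compound 3, lie within the scatter of one another. No measurement on hand bears on this result.

The compounds shown leave open whether a group other than a halogen at this place, such as an amine, a methoxy group or a carboxylic acid, would move the number beyond the scatter. They also leave open what a change to the shared core would do.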